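Fluoromethyl in place of methyl on a nitrophenyl chromene core

A few compounds are considered here, and "the series" means these few. Any claim that something is new, unique, unknown or untested is made for them only; others in the source may bear on it.

Measured compounds:
- compound 1, `C/N=C(/S)C1=CC(C)(CF)Oc2ccc([N+](=O)[O-])cc21`, 77.1%
- compound 2, `C/N=C(/S)C1=CC(CF)(CF)Oc2ccc([N+](=O)[O-])cc21`, 74.5%
- compound 3, `CC1(C)C=C(C(=O)NCCC#N)c2cc([N+](=O)[O-])ccc2O1`, 73.1%

Of the compounds shown here, three have been measured in a functional assay on the whole organism (aorta) with Rattus norvegicus as the target; on this read-out higher numbers stand for larger maximal responses and lower numbers for smaller maximal responses. Compound 1 gives 77.1%, compound 2 gives 74.5% and compound 3 gives 73.1%. All three numbers lie close together, and none of the pairs is separated by more than the usual scatter of this kind of measurement.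

Compound 2 arises from compound 1 by one change, (fluoro in place of hydrogen on a saturated chain carbon bound to a saturated ring carbon), the same difference cut one bond further out reading methyl to fluoromethyl. In this assay the step is a number 2.6 percentage points lower from compound 1 to compound 2 (within the scatter).

Compound 4, `CC1(CF)C=C(C(=O)NCCC#N)c2cc([N+](=O)[O-])ccc2O1`, has not yet been measured in this assay. Within the data shown here, it arises from compound 3 by fluoro in place of hydrogen on a saturated chain carbon bound to a saturated ring carbon, which is the same change as the one from compound 1 to compound 2, made at the same kind of place. The difference between the core of compound 3 and the core of compound 1 is not broken down here.

Among the measured compounds shown here, since the one measured example of this change gave a number 2.6 percentage points lower from compound 1 to compound 2 (within the scatter), the step is expected to be small again, a number 2.1 percentage points lower from compound 3 to compound 4 (within the scatter). Compound 4 is therefore estimated to give 71% in this assay, with the likely range running from 62% to 80%.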

Compound 4, intrinsic activity: the largest response reached, in percent of the reference agonist's: 71%
Compound 4: middle estimate and measured number agree at the digits printed, within the range that was stated.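

In this assay, methyl to fluoromethyl on the core of compound 3 gave a number 2.1 percentage points lower from compound 3 to compound 4 (within the scatter), and this step matches the earlier one on the core of compound 1: the same change on two cores in this assay, a number 2.6 percentage points lower (within the scatter) from compound 1 to compound 2 and a number 2.1 percentage points lower (within the scatter) from compound 3 to compound 4, 0.5 percentage points apart, within the scatter of two such steps

Within these two pairs, the change therefore carries from one core to the other as a small step that cannot be told from the usual scatter, and the exchange of the side group on the double-bonded ring carbon, seen as a number 6.1 percentage points lower from compound 1 to compound 4 (within the scatter), likewise stays within it. Among these compounds, this does not show that fluoro in place of hydrogen has any real effect on the maximal response, nor that the agreement would hold on a third core, since it rests on only two pairs whose steps both lie within the scatter.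

The compounds shown leave open whether a trifluoromethyl or a longer chain such as ethyl, in place of the methyl on the saturated ring carbon, would give a step beyond the scatter. They also leave open how the same change would behave on a core that carries an amine or a carboxylic acid as its side group.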